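Propyl in Place of Hydrogen on the Shared Core

The source may hold more compounds than are shown below. What is called first, only, known or untested is meant among the compounds shown, and "the series" means these compounds.

Compound 2 `O=C(Nc1cc(C(F)(F)F)cc(C(F)(F)F)c1)c1cnc(Cl)nc1` gives 300 nM in an assay on Jurkat cells for activation of nuclear factor NF-kappa-B complex (Homo sapiens) (on this read-out lower numbers stand for stronger inhibition and higher numbers for weaker inhibition), the lowest of the two numbers shown. Compound 1 `O=C(Nc1cc(C(F)(F)F)cc(C(F)(F)F)c1)c1cnc(Cl)nc1C(F)(F)C(F)(F)F`, which carries a pentafluoroethyl group on the same carbon, gives 800 nM. The step of a 2.7-fold lower number from compound 1 to compound 2 (0.43 log units; beyond the scatter) shows that clearing that position helps. Compound 3 `O=C(Nc1cc(C(F)(F)F)cc(C(F)(F)F)c1)c1cnc(-c2ccccc2)nc1` reaches only the assay limit of > 10000 nM. The step of an at least 33-fold higher number from compound 2 to compound 3 (1.52 log units; beyond the scatter) shows that a phenyl in place of chloro costs a great deal. Compound 4 `CCCc1nc(Cl)ncc1C(=O)Nc1cc(C(F)(F)F)cc(C(F)(F)F)c1` differs from compound 2 by propyl in place of hydrogen on an aromatic carbon. This partly reverses the first step, putting a chain back onto that carbon, so a modest rise in the number is expected. Compound 4 is therefore estimated at 700 nM, within 250 nM to 2500 nM. The expected step is a 2.3-fold higher number from compound 2 to compound 4 (0.37 log units; beyond the scatter).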

Compound 4, half-maximal inhibitory concentration: 500 nM
Compound 4: middle estimate off by 1.4-fold (0.15 log units), on the high side, and the stated range covers the measured number.
By their numbers in this assay, from the lowest: compounds 2, 4 and 1 (each within the scatter of the next, the first and the last beyond it). At a limit, above all of these: compound 3.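

Propyl in place of hydrogen on this carbon brings a 1.7-fold higher number from compound 2 to compound 4 (0.22 log units; within the scatter) and so the position accepts a propyl chain. Propyl in place of pentafluoroethyl brings a 1.6-fold lower number from compound 1 to compound 4 (0.20 log units; within the scatter) and so these two chains cannot be told apart here, although hydrogen and pentafluoroethyl on this carbon differ beyond the scatter. Nothing shown explains why this carbon accepts propyl. Going by these compounds, whether a longer chain such as hexyl would still be accepted stays open. So does the effect of an amine on this carbon.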